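Ring Exchange at the Ether Oxygen: What Compound 3 May Give

The source may hold more compounds than are shown below. What is called first, only, known or untested is meant among the compounds shown, and "the series" means these compounds.

For the measured compounds named here, in an assay on isolated protein for inhibition of Rho-associated protein kinase 2 (Homo sapiens), read by scintillation counting, radiometric assay and 33P incorporation, with a stated time of 40 min, in the presence of a further agent that is not named here (on this read-out lower numbers stand for stronger inhibition and higher numbers for weaker inhibition), compound 2 `CN(C)c1ccc(C(=O)Nc2cccc(NC(=O)COc3ccc4c(c3)OCCC4=O)c2)cc1` gives 85 nM, the lowest of the two numbers so far, while compound 1 `CC(=O)c1ccc(OCC(=O)Nc2cccc(NC(=O)c3ccc(N(C)C)cc3)c2)cc1F` gives 98 nM; the step of a 1.2-fold lower number from compound 1 to compound 2 (0.06 log units; within the scatter) does not set the two apart. Compound 3 `CN(C)c1ccc(C(=O)Nc2cccc(NC(=O)COc3ccc4occc(=O)c4c3)c2)cc1` differs from compound 2 by a group of 11 heavy atoms (9 carbon, 2 oxygen; one six-membered aromatic ring of carbon only, one six-membered aromatic ring with 1 hetero atom) in place of a group of 11 heavy atoms (9 carbon, 2 oxygen; one six-membered non-aromatic ring with 1 hetero atom, one six-membered aromatic ring of carbon only), on an oxygen on a saturated carbon, so the size of the group on that oxygen stays the same and only the ring with one hetero atom changes from non-aromatic to aromatic. Going by the values given here, the single measured step that touches this position, from compound 1 to compound 2, stayed within the scatter, and no step beyond the scatter is known at all, so there is no basis for expecting a large move in this assay. The expected step is therefore a 1.1-fold higher number from compound 2 to compound 3 (0.02 log units; within the scatter), essentially no change. Compound 3 is estimated at 90 nM, with a range from 35 nM to 250 nM.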

Compound 3, half-maximal inhibitory concentration: > 10000 nM
Compound 3: a limit, no number; the forecaster's own chance of this, stated with the estimate: 3%; middle value at least 110-fold (2.04 log units) away from the limit.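

In this assay, the position on the oxygen on a saturated carbon proves far less tolerant than the first two compounds suggested. Changing one ring with 1 hetero atom from non-aromatic to aromatic gives an at least 110-fold higher number from compound 2 to compound 3 (2.07 log units; beyond the scatter), although the heavy-atom count, the double bond outside aromatic rings and the hydrogen-bond acceptor count all stay the same, and the comparison with the other measured group gives an at least 100-fold higher number from compound 1 to compound 3 (2.00 log units; beyond the scatter). Compound 3 stands at a limit of the assay and has no number: the limit of > 10000 nM in this assay, at which 1 of the 3 values shown sits.

The compounds shown do not tell whether the aromatic ring with 1 hetero atom alone accounts for this large step. They also leave open how a plain phenyl ring, or an aromatic ring carrying an amine or a carboxylic acid, would fare on that oxygen.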